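A few compounds are considered here, and "the series" means these few. Any claim that something is new, unique, unknown or untested is made for them only; others in the source may bear on it.

Measured so far in a physicochemical assay for lipophilicity, read by HPLC, measured as chromatographic lipophilicity, at pH 7.4; a lower number here means a more polar compound, a higher number a more lipophilic compound:
compound 1, `N#Cc1ccc(N2CCC(C(=O)N3N=CC[C@H]3c3cc(F)cc(F)c3)CC2)nn1`: 4.8
compound 2, `CC(C)(C)C(=O)N1N=CCC1c1ccc(S(C)(=O)=O)cc1`: 4.1

Compound 2 stands lowest of the two numbers in this assay; the nearest is compound 1, whose value is higher by a gap beyond the usual scatter. Going by the values given here, the two measured compounds differ in several places at once, so no single-point step between them is known, and nothing measured yet mirrors the change to compound 3, `Cc1ccc(C2CC=NN2C(=O)C(C)(C)C)cc1`.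

Compound 3 differs from compound 2 as follows: methyl in place of methylsulfonyl on an aromatic carbon. Methylsulfonyl leaves and methyl enters on an aromatic carbon of a six-membered aromatic ring of carbon only; the rest of the structure is unchanged.

For compound 3 the step of a number 1.70 log units higher from compound 2 to compound 3 (beyond the scatter) is expected to be upward and well beyond the scatter, as this assay reads lipophilicity. Compound 3 is therefore estimated at 5.8, within 5.2 to 6.4.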

Compound 3, distribution coefficient: 6.4
Estimate against measurement, compound 3: 0.60 log units below; the measured number falls inside the stated range.
By their numbers in this assay, from the lowest: compound 2; then compound 1; then compound 3.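

In this assay, going by these compounds alone, the change at this aromatic carbon, para to a large group, gives the first single-place comparison: methyl in place of methylsulfonyl is a number 2.30 log units higher from compound 2 to compound 3 (beyond the scatter) and counts as a large step. With the rest of the structure unchanged, the step belongs to this one swap, in which methylsulfonyl takes 4 heavy atoms and 2 hydrogen-bond acceptors with it and methyl brings 1 heavy atom and no acceptor. No measured information accounts for the size of the step.

One swap cannot show which feature of the leaving group carries the step, nor how a methoxy group, an amine or a carboxylic acid on the same aromatic carbon would read. Also open, from the compounds shown here alone, is whether the same swap gives a step of similar size on the core of compound 1.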